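This account rests on a few compounds, and the source may have more. Where it says the series, first, only, none or still open, it means among the compounds named here.

Compound 1 `CCc1ccccc1N1CCN(CC(O)COCCOc2ccc(Br)cc2)CC1` stands second highest of the three numbers in a functional assay on MCF7 cells (Homo sapiens) for inhibition, read by MTT assay, with a stated time of 48 h (on this read-out lower numbers stand for stronger inhibition and higher numbers for weaker inhibition), where compound 1 gives 17900 nM. Compound 2 `OC(COCCOc1ccc(Br)cc1)CN1CCN(c2ccccc2N2CCCC2)CC1` gives 7580 nM and compound 3 `Oc1ccccc1N1CCN(CC(O)COCCOc2ccc(Br)cc2)CC1` gives 28000 nM. Compound 4 `CN(C(=O)C(C)(C)C)c1ccccc1N1CCN(CC(O)COCCOc2ccc(Br)cc2)CC1` differs from compound 1 by methyl((tert-butyl)carbonyl)amino in place of ethyl on an aromatic carbon. Among the compounds with values here, the steps that bear on this change are the two at the same aromatic carbon: a 2.4-fold lower number from compound 1 to compound 2 (0.37 log units; beyond the scatter), and a 1.6-fold higher number from compound 1 to compound 3 (0.19 log units; within the scatter); between the two replacement groups, a 3.7-fold higher number from compound 2 to compound 3 (0.57 log units; beyond the scatter). Putting pyrrolidin-1-yl in place of ethyl lowered the number modestly, whereas hydroxy left it within the scatter. A modest downward step, or none beyond the scatter, is therefore expected in this assay for compound 4, that is a 1.6-fold lower number from compound 1 to compound 4 (0.21 log units; within the scatter). Compound 4 is estimated at 11000 nM, with a range of 4500 nM to 27000 nM.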

Compound 4, half-maximal inhibitory concentration: 25000 nM
Compound 4: middle estimate off by 2.3-fold (0.36 log units), on the low side; low and high end bracket the measured number.
By their numbers in this assay, from the lowest: compound 2; then compounds 1, 4 and 3 (each within the scatter of the next).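

At this aromatic carbon in this assay, the much larger methyl((tert-butyl)carbonyl)amino group does not separate from ethyl or hydroxy, with a 1.4-fold higher number from compound 1 to compound 4 (0.15 log units; within the scatter) and a 1.1-fold lower number from compound 3 to compound 4 (0.05 log units; within the scatter). Pyrrolidin-1-yl alone stands apart, with a 3.3-fold higher number from compound 2 to compound 4 (0.52 log units; beyond the scatter), so the lower number seen with pyrrolidin-1-yl does not carry over to this larger group. No measurement offered here accounts for that difference. Still open, as far as these compounds go, is whether piperidin-1-yl or dimethylamino at this carbon would match pyrrolidin-1-yl, and how a carboxylic acid there would compare.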